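The source may hold more compounds than are shown below. What is called first, only, known or untested is meant among the compounds shown, and "the series" means these compounds.

In an ADME assay on the whole organism (Rattus norvegicus) for pharmacokinetics, at a dose of 2 mg/kg by the intravenous route (on this read-out lower numbers stand for slow clearance and higher numbers for fast clearance), compound 1 `CCc1cccc(CC)c1NC(=O)c1ccn(-c2nc(Nc3ccc(N4CCC(N5CCN(C)CC5)CC4)cc3OC)nc3[nH]ccc23)c1` gives 68 mL/min/kg, compound 2 `CCc1cccc(CC)c1NC(=O)c1cc(-c2nc(Nc3ccc(N4CCC(N5CCN(C)CC5)CC4)cc3OC)nc3[nH]ccc23)n(C)n1` gives 15 mL/min/kg and compound 3 `CCc1cccc(CC)c1N1CCn2cc(-c3nc(Nc4ccc(N5CCC(N6CCN(C)CC6)CC5)cc4OC)nc4[nH]ccc34)cc2C1=O` gives 52 mL/min/kg. Compound 3 thus sits within the scatter of compound 1, while compound 2 lies lower than compound 3 by more than the scatter. Compound 4 `CCc1cccc(CC)c1N1CCn2cc(-c3nc(Nc4ccc(N5CCC(C(=O)N(C)CCN(C)C)CC5)cc4OC)nc4[nH]ccc34)cc2C1=O` differs from compound 3 in one place, with (2-(dimethylamino)ethyl)(methyl)carbamoyl in place of 4-methylpiperazin-1-yl on a saturated ring carbon. Among the compounds with values here, no measured pair shows what such an exchange does in this assay. The expected step, a 1.2-fold lower number from compound 3 to compound 4 (0.06 log units; within the scatter), is therefore small, within the scatter and without a firm direction. For compound 4 the estimated clearance is 45 mL/min/kg, with an expected range of 22 mL/min/kg to 85 mL/min/kg.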

Compound 4, clearance: 27 mL/min/kg
Estimate against measurement, compound 4: 1.7-fold (0.22 log units) above, and the stated range covers the measured number.
By their numbers in this assay, from the lowest: compounds 2, 4, 3 and 1 (each within the scatter of the next, the first and the last beyond it).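

In this assay, within the data shown here, the exchange at this saturated ring carbon gives a 1.9-fold lower number from compound 3 to compound 4 (0.28 log units; within the scatter), the first measured step at this position. In this single pair, the open-chain (2-(dimethylamino)ethyl)(methyl)carbamoyl takes the place of the ring-bearing 4-methylpiperazin-1-yl without a step beyond the scatter. Nothing available explains the step. From the compounds shown here alone, whether a morpholine, a simple dimethylamino group or a carboxylic acid on this carbon would move clearance beyond the scatter remains open. Also open, going by these compounds, is whether a longer chain between the two nitrogens would leave it within the scatter.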